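Series notes: aryl swap on the shared core

A few compounds are considered here, and "the series" means these few. Any claim that something is new, unique, unknown or untested is made for them only; others in the source may bear on it.

Compound 3 `Cc1ccc(-c2nnc(-c3sc(-c4cccnc4)nc3C)o2)cc1` is known in an ADME assay on HCT-116 cells (Homo sapiens) for cytotoxicity, read by MTT assay (a higher number here means that more compound is tolerated, a lower number that less compound is tolerated), only as a limit: compound 3 gives > 100 ug/mL. Compound 1 `Cc1nc(-c2cccnc2)sc1-c1nnc(-c2ccc(Br)cc2)o1` likewise sits at a limit in this assay, with > 100 ug/mL. Compound 2 `Cc1cccc(-c2nnc(-c3sc(-c4cccnc4)nc3C)o2)c1` also reaches only a limit, > 100 ug/mL. All three values sit at the limit (the limit of > 100 ug/mL in this assay, at which 3 of the 3 values shown sit), so the steps a step that the two limits leave unreadable from compound 1 to compound 2, a step that the two limits leave unreadable from compound 1 to compound 3 and a step that the two limits leave unreadable from compound 2 to compound 3 give no readable size. Compound 4 `Cc1nc(-c2cccnc2)sc1-c1nnc(-c2cccnc2)o1` differs from compound 3 by pyridin-3-yl in place of 4-methylphenyl on an aromatic carbon. Within the data shown here, none of the measured steps covers this change, and the three known values fix only a floor. Compound 4 is therefore expected to remain at the limit, with an expected step that the limit leaves unreadable from compound 3 to compound 4 of no readable size. The estimate for compound 4 is 120 ug/mL, between 60 ug/mL and 300 ug/mL.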

Compound 4, half-maximal cytotoxic concentration: > 100 ug/mL
Compound 4: a limit, no number; the forecaster's own chance of this, stated with the estimate: 75%; the middle value lies beyond the limit too.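

In this assay, among these compounds, compound 4 gives > 100 ug/mL, a limit, so no step from compound 1, compound 2 or compound 3 to compound 4 can be read. The compounds shown leave open whether any aryl swap on the shared core changes the tolerated concentration: the limit of > 100 ug/mL in this assay, at which 4 of the 4 values shown sit.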